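Adding a Second Methyl at the Assay Limit

The source may report more compounds than this note shows. Statements on the series, on what has been measured and on what is new or still open speak of the compounds shown alone.

In a functional assay on MDA-MB-231 cells (Homo sapiens) for cytotoxicity, read by MTT assay, with a stated time of 48 h (on this read-out higher numbers stand for weaker inhibition and lower numbers for stronger inhibition), compound 3 (`Cc1cccc(NC(=O)NCCCCC(c2ccc(F)cc2)c2ccc(F)cc2)c1`) gives > 20000 nM as a limit, not a number. Compound 1 (`Cc1ccc(NC(=O)NCCCCC(c2ccc(F)cc2)c2ccc(F)cc2)cc1`) gives > 20000 nM as a limit too. Compound 3 therefore stands at the limit of > 20000 nM in this assay, at which 2 of the 3 values shown sit, and has no exact value. Only compound 2 (`O=C(NCCCCC(c1ccc(F)cc1)c1ccc(F)cc1)Nc1cccc(Cl)c1`) gives a true number, with 5070 nM in this assay.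

Compound 4 (`Cc1ccc(NC(=O)NCCCCC(c2ccc(F)cc2)c2ccc(F)cc2)cc1C`) turns the 3-methylphenyl of compound 3 into 3,4-dimethylphenyl, with methyl in place of hydrogen on an aromatic carbon, ortho to a methyl group: methyl in place of hydrogen on an aromatic carbon is the whole change.

Moving the methyl gives a step that the two limits leave unreadable from compound 1 to compound 3 and so reveals little. Chloro in place of methyl is the only clear contrast, seen in an at least 3.9-fold higher number from compound 2 to compound 3 (0.59 log units; beyond the scatter) and in an at least 3.9-fold lower number from compound 1 to compound 2 (0.59 log units; beyond the scatter) as well. Compound 4 has no chloro, but carries methyl in both places tried so far, so no step beyond the scatter is expected. The expected change is a step that the limit leaves unreadable from compound 3 to compound 4 and may again be hidden by the limit. For compound 4 the estimated value is 22000 nM within an expected range of 10000 nM to 45000 nM in this assay.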

Compound 4, half-maximal inhibitory concentration: > 20000 nM
Compound 4: only a limit was reported; the forecaster's own chance of this, stated with the estimate: 65%; the middle value does not contradict the limit.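

Methyl in both places tried leaves these compounds at the same ceiling: the limit of > 20000 nM in this assay, at which 3 of the 4 values shown sit.

The steps to compound 4 from compound 1 and from compound 3 cannot be read, so the added methyl, ortho to a methyl group, brings no change that can be seen in this assay. The new information lies in the comparison with the chloro compound: the 3,4-dimethylphenyl group still gives an at least 3.9-fold higher number from compound 2 to compound 4 (0.59 log units; beyond the scatter), so a second methyl does not reach the value of compound 2.

From the compounds shown here alone, only compound 2 gives a true number, so it remains open whether this stronger result is specific to chloro or would also appear with a bromo or a nitrile in its place. Going by these compounds, how a second chloro in place of the added methyl, or a longer chain in the shared core, would read also stays open.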